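The source may report more compounds than this note shows. Statements on the series, on what has been measured and on what is new or still open speak of the compounds shown alone.

Compound 1, `C=CS(=O)(=O)N1CCN(c2ncnc3sc(-c4ccccc4)cc23)CC1`, gives 21100 nM in a functional assay on MDA-MB-436 cells (Homo sapiens) for antiproliferative activity, read by MTT assay, with a stated time of 48 h; a lower number here means a stronger inhibitor, a higher number a weaker inhibitor. Compound 2, `C=CS(=O)(=O)N1CCN(c2ncnc3sc(-c4ccc(OC)cc4)cc23)CC1`, differs from it by the change (methoxy in place of hydrogen on an aromatic carbon); in this assay compound 2 gives 28400 nM, so that the step is a 1.3-fold higher number from compound 1 to compound 2 (0.13 log units; within the scatter). Compound 3, `CN1CCN(c2ccc(-c3cc4c(N5CCN(C(=O)Nc6ccccc6)CC5)ncnc4s3)cc2)CC1`, carries a different core, and the difference between the two cores is not broken down here; in this assay compound 3 gives 7090 nM, the lowest number of the three measured compounds, with compound 1 nearest to it and compound 2 furthest from it.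

Compound 4, `COc1ccc(NC(=O)N2CCN(c3ncnc4sc(-c5ccc(N6CCN(C)CC6)cc5)cc34)CC2)cc1`, is not yet measured. Among the compounds with values here, it differs from compound 3 by methoxy in place of hydrogen on an aromatic carbon, which is the same change as the one from compound 1 to compound 2, made on the same kind of place. Because that earlier step was a 1.3-fold higher number from compound 1 to compound 2 (0.13 log units; within the scatter), the step from compound 3 to compound 4 is expected to stay small as well, estimated at a 1.2-fold higher number from compound 3 to compound 4 (0.08 log units; within the scatter). The estimate for compound 4 in this assay is therefore 8500 nM, with a likely range from 4000 nM to 18000 nM.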

Compound 4, half-maximal inhibitory concentration: 30100 nM
For compound 4 the middle estimate is 3.5-fold (0.55 log units) below the measured one, and the stated range ends below it.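

In this assay, methoxy in place of hydrogen on an aromatic carbon gives a 4.2-fold higher number from compound 3 to compound 4 (0.63 log units; beyond the scatter), and this step does not match the earlier one made with the same change: the same change on two cores in this assay, a 1.3-fold higher number (0.13 log units; within the scatter) from compound 1 to compound 2 and a 4.2-fold higher number (0.63 log units; beyond the scatter) from compound 3 to compound 4, 3.2-fold (0.50 log units) apart, beyond the scatter of two such steps. The size of the step therefore did not carry from one core to the other in this series, and a small step on one core gave no safe guide to the step on the other. These two pairs do not show which structural difference between them sets the gap, since the cores differ and the change on the second core reads phenylcarbamoyl to (4-methoxyphenyl)carbamoyl, nor do they show how a third core would respond.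

The compounds shown leave open whether a group such as an amine, a hydroxyl or a longer chain like ethoxy, set in the same place, would follow the methoxy step on either core. They also leave open whether hydrogen is the better choice at that place across the series as a whole.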